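Replacing the 4-chloro-3-nitrophenyl group of compound 3

The source may hold more compounds than are shown below. What is called first, only, known or untested is meant among the compounds shown, and "the series" means these compounds.

Compound 1 `O=C(NCCCCC(c1ccc(F)cc1)c1ccc(F)cc1)Nc1ccc(I)cc1`: 11800 nM
Compound 2 `Cc1ccc(NC(=O)NCCCCC(c2ccc(F)cc2)c2ccc(F)cc2)cc1`: > 20000 nM (a limit of the assay, not a number)
Compound 3 `O=C(NCCCCC(c1ccc(F)cc1)c1ccc(F)cc1)Nc1ccc(Cl)c([N+](=O)[O-])c1`: 4060 nM

In a functional assay on MDA-MB-231 cells (Homo sapiens) for cytotoxicity, read by MTT assay, with a stated time of 48 h (a higher number here means a weaker inhibitor, a lower number a stronger inhibitor), compound 3 has the lowest of the two actual numbers, at 4060 nM. The next compound to be tested is compound 4 `O=C(NCCCCC(c1ccc(F)cc1)c1ccc(F)cc1)Nc1ccc(Cl)cc1C(F)(F)F`. In it, 4-chloro-2-(trifluoromethyl)phenyl takes the place of 4-chloro-3-nitrophenyl on an amide-type nitrogen: 4-chloro-2-(trifluoromethyl)phenyl in place of 4-chloro-3-nitrophenyl on an amide-type nitrogen.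

Two measured steps change the group at this same nitrogen, and both arrive at the group that compound 4 gives up. The first is a 2.9-fold lower number from compound 1 to compound 3 (0.46 log units; beyond the scatter). The second is an at least 4.9-fold lower number from compound 2 to compound 3 (0.69 log units; beyond the scatter). Both steps favoured 4-chloro-3-nitrophenyl, so losing it is expected to raise the number somewhat, although the retained chloro substituent may limit the change. The expected step is a 1.7-fold higher number from compound 3 to compound 4 (0.24 log units; within the scatter), towards a weaker inhibitor. For compound 4 the estimate is 7000 nM, with an expected range from 2500 nM to 18000 nM.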

Compound 4, half-maximal inhibitory concentration: > 20000 nM
Compound 4: a limit, no number; the forecaster's own chance of this, stated with the estimate: 15%; middle value at least 2.8-fold (0.45 log units) away from the limit.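

The value of compound 4 is a limit of the assay, not a number. Even so, replacing 4-chloro-3-nitrophenyl with 4-chloro-2-(trifluoromethyl)phenyl gives an at least 4.9-fold higher number from compound 3 to compound 4 (0.69 log units; beyond the scatter), so keeping a chloro substituent on the ring does not by itself preserve the cytotoxicity of compound 3, while the other readable step, an at least 1.6-fold higher number from compound 1 to compound 4 (0.22 log units; that floor lies within the scatter), does not separate that pair beyond the scatter. The step between compound 2 and compound 4 cannot be read because both sit at the same limit: the limit of > 20000 nM in this assay, at which 2 of the 4 values shown sit.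

The compounds shown do not separate the loss of the nitro group from the arrival of the trifluoromethyl group, since both happen in one change. As far as these compounds go, how an amine or a nitrile in place of the nitro group would read in this assay also stays open.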